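From 2-methylphenyl to 4-methylphenyl: an expected small step

The source may report more compounds than this note shows. Statements on the series, on what has been measured and on what is new or still open speak of the compounds shown alone.

In a physicochemical assay for solubility, read by HPLC, in phosphate buffer, with a stated time of 24 h, at pH 7.4, tested at 100 uM (on this read-out higher numbers stand for higher solubility and lower numbers for lower solubility), compound 1 (`O=C(CCCCCNc1c(Nc2ccccc2)c(=O)c1=O)NO`) gives 47000000 nM, and compound 2 (`Cc1ccccc1[C@H](C)Nc1c(NCCCCCC(=O)NO)c(=O)c1=O`) gives 92000000 nM. Within the data shown here, these are the only two numbers so far, and they lie within the scatter of each other. Compound 3 (`Cc1ccc([C@H](C)Nc2c(NCCCCCC(=O)NO)c(=O)c2=O)cc1`) has the same atoms as compound 2, joined differently (4-methylphenyl in place of 2-methylphenyl on a saturated chain carbon bound to a nitrogen on an aromatic ring and a saturated chain carbon). Among the measured compounds shown here, no measured pair yet shows how a change of this kind plays out. In this assay no step beyond the scatter is therefore expected, and the estimated step is a 1.2-fold lower number from compound 2 to compound 3 (0.06 log units; within the scatter). For compound 3 the estimated value is 80000000 nM, with an expected range from 40000000 nM to 160000000 nM.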

Compound 3, solubility: 76000000 nM
The estimate for compound 3 lay 1.1-fold (0.02 log units) above the measured number, and the stated range covers the measured number.
By their numbers in this assay, from the lowest: compounds 1, 3 and 2 (each within the scatter of the next).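

Placing 4-methylphenyl in place of 2-methylphenyl on a saturated chain carbon bound to a nitrogen on an aromatic ring and a saturated chain carbon gives the first measured step of this kind in this assay (a 1.2-fold lower number from compound 2 to compound 3 (0.08 log units; within the scatter)). At this position, compound 2 and compound 3 cannot be told apart on this read-out, so this exchange of isomeric groups has no resolved effect. Nothing measured here offers a reason for this result.

The compounds shown leave open whether an amine or a carboxylic acid in place of the methyl on that phenyl ring would shift the number beyond the scatter in this assay.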